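Moving Away from the Lowest Number with a Furan

A few compounds are considered here, and "the series" means these few. Any claim that something is new, unique, unknown or untested is made for them only; others in the source may bear on it.

In a functional assay on HL-60 cells (Homo sapiens) for inhibition, read by MTT assay, with a stated time of 48 h, tested at 10 uM (on this read-out higher numbers stand for more inhibition of growth at the one concentration tested and lower numbers for less inhibition of growth), compound 1 (`COc1ccc(COc2cc(O)c3c(=O)cc(C)oc3c2[C@H]2CCN(C)C[C@H]2O)cc1`) gives 23% and compound 2 (`Cc1cc(=O)c2c(O)cc(OCc3ccc([N+](=O)[O-])cc3)c([C@H]3CCN(C)C[C@H]3O)c2o1`) gives 14% while compound 3 (`Cc1cc(=O)c2c(O)cc(OCc3ccccc3Br)c([C@H]3CCN(C)C[C@H]3O)c2o1`) gives 3% as the lowest of the three numbers. Compound 4 (`Cc1cc(=O)c2c(O)cc(OCc3ccco3)c([C@H]3CCN(C)C[C@H]3O)c2o1`) carries furan-2-yl in place of 2-bromophenyl on a saturated chain carbon bound to an oxygen on an aromatic ring. Two modest measured steps changed the group at this same place (a number 11 percentage points lower from compound 2 to compound 3 (beyond the scatter) and a number 20 percentage points lower from compound 1 to compound 3 (beyond the scatter)) and both ended at 2-bromophenyl. No furan has been measured yet, so the expected step in this assay is a small upward one within the scatter (a number 7 percentage points higher from compound 3 to compound 4 (within the scatter)). For compound 4 the estimated value is 10% within a range of 0% to 22% on this scale.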

Compound 4, percent growth inhibition at one concentration: 32%
Estimate against measurement, compound 4: 22 percentage points below; the measured number lies above the stated range.
By their numbers in this assay, from the lowest: compound 3; then compounds 2, 1 and 4 (each within the scatter of the next, the first and the last beyond it).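

In this assay, replacing a six-membered aromatic ring of carbon only with furan-2-yl at this place gives a number 29 percentage points higher from compound 3 to compound 4 (beyond the scatter) and a number 18 percentage points higher from compound 2 to compound 4 (beyond the scatter), while the comparison with 4-methoxyphenyl gives a number 9 percentage points higher from compound 1 to compound 4 (within the scatter). So a five-membered ring with an oxygen can stand here without falling to the low number of the 2-bromophenyl compound, and furan-2-yl does not separate from 4-methoxyphenyl. Nothing available explains why the number changes with these groups. Still open, from the compounds shown here alone, is whether a ring is needed here at all, or whether a thiophene, an amine or a longer chain on this carbon would move the number beyond that of compound 4.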